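The compounds below may be only part of what the source reports. "The series", "measured", "known", "first", "only" and "open" are said of these compounds alone.

Measured in a functional assay on the whole organism with Mus musculus as the target, in the rotarod test; a lower number here means that less compound is needed, a higher number that more compound is needed for the effect:
- Compound 1 `CC(=O)NCC(=O)Nc1ccc(Cl)cc1C(=O)c1ccccc1`: > 100 mg/kg, a limit
- Compound 2 `CC(C)NCC(=O)NCC(=O)N(C)c1ccc(Cl)cc1C(=O)c1ccccc1Cl`: 13 mg/kg
- Compound 3 `NC(C(=O)NCC(=O)Nc1ccc(Cl)cc1C(=O)c1ccccc1)c1ccccc1`: > 100 mg/kg, a limit

Going by the values given here, compound 2 gives 13 mg/kg, the only true number in this small set. Compound 1 and compound 3 both meet (the limit of > 100 mg/kg in this assay, at which 2 of the 3 values shown sit).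

Compound 4 `CN(C(=O)CNC(=O)CN1CCN(c2ccccc2)CC1)c1ccc(Cl)cc1C(=O)c1ccccc1Cl` differs from compound 2 in one place, where 4-phenylpiperazin-1-yl takes the place of isopropylamino: 4-phenylpiperazin-1-yl in place of isopropylamino on a saturated chain carbon bound to a carbonyl carbon.

Among the compounds with values here, the only measured step that bears on this swap is a step that the two limits leave unreadable from compound 1 to compound 3. It also brings in a group with an aromatic ring, but it offers no size to carry over. The expectation therefore rests on compound 2 at 13 mg/kg and on the scale of the swap, so it is loose.

In this assay, a moderate shift towards needing more compound is expected, which would be a 2.3-fold higher number from compound 2 to compound 4 (0.36 log units; beyond the scatter). For compound 4 the estimated value is 30 mg/kg, with an expected range of 8 mg/kg to 110 mg/kg. A result reported only as a limit also remains possible.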

Compound 4, dose for half-maximal effect: > 100 mg/kg
Compound 4 gave a limit, no number; the forecaster's own chance of this, stated with the estimate: 30%; at least 3.3-fold (0.52 log units) between middle value and limit.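

In this assay, going by these compounds alone, 4-phenylpiperazin-1-yl in place of isopropylamino on a saturated chain carbon bound to a carbonyl carbon gives an at least 7.6-fold higher number from compound 2 to compound 4 (0.88 log units; beyond the scatter); this is the first step in the set with a readable size, as the only earlier step cannot be read. The position therefore responds to what sits on it: exchanging a group with no ring for one with a non-aromatic and an aromatic ring clearly raises the dose needed. Compound 4 is reported only as a limit, so the step has a minimum size but no exact one: the limit of > 100 mg/kg in this assay, at which 3 of the 4 values shown sit.

The compounds shown do not separate the piperazine ring from its phenyl group, a question that plain piperazin-1-yl could address. They also leave open how a smaller amine such as dimethylamino would compare with isopropylamino at this position.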